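A few compounds are considered here, and "the series" means these few. Any claim that something is new, unique, unknown or untested is made for them only; others in the source may bear on it.

Compound 1 `COc1ccc(/C=C/C[C@H]2C[C@H]([C@H](O)c3ccc(OC)c(OC)c3)CO[C@@H]2c2ccc(OC)c(OC)c2)cc1OC` is a tetrahydropyran bearing three dimethoxyphenyl groups, one of them on a hydroxy-substituted side chain and one at the end of an alkenyl chain. For the measured compounds named here, in a functional assay on HeLa cells (Homo sapiens) for cytotoxicity, read by WST assay, with a stated time of 48 h (a higher number here means a weaker inhibitor, a lower number a stronger inhibitor), compound 1 gives 34600 nM, which places it as a weak inhibitor of cell growth; it is the only number in this assay. Compound 2 `COc1ccc(/C=C/C[C@H]2C[C@@H]([C@@H](OC)c3ccc(OC)c(OC)c3)CO[C@@H]2c2ccc(OC)c(OC)c2)cc1OC`, its methyl ether at the side-chain oxygen, reaches only > 100000 nM in this assay, which is a limit of the measurement rather than a number, as noted in the limit of > 100000 nM in this assay, at which 1 of the 2 values shown sits.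

Compound 3 `COc1ccc(/C=C/C[C@@H]2C[C@@H]([C@@H](O)c3ccc(OC)c(OC)c3)CO[C@H]2c2ccc(OC)c(OC)c2)cc1OC` has the same atoms and bonds as compound 1 but differs in how it is drawn in space: the two compounds have the same atoms and bonds and differ only in configuration as drawn: 4 of 5 stereo elements differ; a stereocentre at a saturated ring carbon is drawn S in compound 1 and R in compound 3; a stereocentre at a saturated ring carbon is drawn S in compound 1 and R in compound 3; a stereocentre at a saturated chain carbon is drawn S in compound 1 and R in compound 3; a stereocentre at a saturated ring carbon is drawn S in compound 1 and R in compound 3. Going by the values given here, no pair of measured compounds differing at one place is available to gauge such a change. Because compound 1 itself gives 34600 nM, close to where this assay stops reporting numbers, the step is expected to fall toward weaker values, and compound 3 is estimated at 55000 nM, within 15000 nM to 150000 nM, meaning an expected step of a 1.6-fold higher number from compound 1 to compound 3 (0.20 log units; within the scatter).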

Compound 3, half-maximal inhibitory concentration: 30600 nM
Compound 3: the middle estimate sits 1.8-fold (0.25 log units) above what was measured; the measured number falls inside the stated range.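

In this assay the comparison gives a 1.1-fold lower number from compound 1 to compound 3 (0.05 log units; within the scatter), so the two compounds cannot be told apart in this test of cell growth. For the compounds shown here, this is the first reading in the set of what configuration alone does, and it shows that four of the five stereo elements can be drawn the other way with no change in the number beyond the usual scatter: the fact that compounds 1 and 3 differ only in the configuration as drawn. For this pair, then, the change at these four centres taken together brings no stronger inhibition, and both compounds remain weak inhibitors.

The four centres changed together, so the result cannot say whether each one is without effect on its own or whether separate effects happen to cancel, and compounds with only one or two centres changed would be needed to settle that. It also leaves open whether any change to the groups themselves could strengthen the inhibition, for example an amine or a carboxylic acid in place of the hydroxy group on the side chain, read in this assay.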